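This account rests on a few compounds, and the source may have more. Where it says the series, first, only, none or still open, it means among the compounds named here.

Among the measured compounds shown here, in a functional assay on PC-3 cells (Homo sapiens), read by MTT assay, with a stated time of 48 h (a lower number here means a stronger inhibitor, a higher number a weaker inhibitor), compound 2 (`CC[C@@H](C)[C@H](NC(=O)c1ccc(C(CC)(CC)c2ccc(OCC(O)C(C)(C)C)c(C)c2)n1CC)C(=O)O`) gives 1900 nM, the lower of the two numbers so far, while compound 1 (`C#CCNC(=O)c1ccc(C(CC)(CC)c2ccc(OCC(O)C(C)(C)C)c(C)c2)n1CC`) gives 16200 nM. The next structure, compound 3 (`CCn1c(C(=O)Oc2ccc(CCO)cc2)ccc1C(CC)(CC)c1ccc(OCC(O)C(C)(C)C)c(C)c1`), differs from compound 2 at the same carbonyl carbon: a group of 10 heavy atoms (8 carbon, 2 oxygen; one six-membered aromatic ring of carbon only) in place of a group of 9 heavy atoms (6 carbon, 1 nitrogen, 2 oxygen; no ring), on a carbonyl carbon. The (1-carboxy-2-methylbutyl)amino group leaves, and the group that enters has a six-membered aromatic ring of carbon only. For the measured compounds named here, one measured step bears on this, an 8.5-fold lower number from compound 1 to compound 2 (0.93 log units; beyond the scatter), so a change at this carbonyl can move the number beyond the scatter. That step swapped one group on an amide nitrogen for another, so it suggests a size but no firm direction. Going by the values given here, compound 2, at 1900 nM, holds the lower of only two numbers, so a modest rise is expected in this assay. The estimated change is a 2.6-fold higher number from compound 2 to compound 3 (0.42 log units; beyond the scatter). Compound 3 is expected at 5000 nM, with an estimated range of 1200 nM to 20000 nM.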

Compound 3, half-maximal inhibitory concentration: 6300 nM
Beside the measured number, compound 3's estimate is 1.3-fold (0.10 log units) below it; the measured number falls inside the stated range.
By their numbers in this assay, from the lowest: compound 2; then compound 3; then compound 1.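

The new group on the carbonyl carbon gives a 3.3-fold higher number from compound 2 to compound 3 (0.52 log units; beyond the scatter) and also a 2.6-fold lower number from compound 1 to compound 3 (0.41 log units; beyond the scatter), so compound 3 sits between the two earlier compounds. Neither compound 1 nor compound 2 has a ring in this group, yet they fall on opposite sides of compound 3, so among these three compounds the presence of a six-membered aromatic ring does not alone set the direction of change. The result also shows that a group without nitrogen can stand on this carbonyl carbon and still give a number within this range, although nothing measured here explains the shifts.

As far as these compounds go, the entering group differs from the earlier groups in its ring, its atoms and its hydrogen-bond counts all at once, so the part that matters remains unknown. An amine carrying the same ring, or a carboxylic acid on a longer chain, would help separate these features.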